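A few compounds are considered here, and "the series" means these few. Any claim that something is new, unique, unknown or untested is made for them only; others in the source may bear on it.

Measured compounds:
- Compound 1 `O=C(Nc1ccccc1)c1cc2n(n1)CCCN(C(=O)c1occc1Cl)C2` gives 30000 nM
- Compound 2 `Cc1ccc(C(=O)N2CCCn3nc(C(=O)Nc4ccccc4)cc3C2)o1` is recorded as "not determined" (no result reported)
- Compound 3 `Cc1ccccc1NC(=O)c1cc2n(n1)CCCN(C(=O)c1occc1C)C2` gives 1100 nM

These values come from an ADME assay on BEAS-2B cells (Homo sapiens) for cytotoxicity, read by fluorescence, with a stated time of 48 h; on this read-out higher numbers stand for lower toxicity in this test and lower numbers for higher toxicity in this test. There, compound 3 stands at 1100 nM, the lower of the two numbers available. For the measured compounds named here, the only other number belongs to compound 1 at 30000 nM, and the gap between the two lies beyond the scatter. Compound 2 adds nothing to the comparison, since it has no result.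

The next compound to be tested is compound 4 `Cc1ccoc1C(=O)N1CCCn2nc(C(=O)Nc3ccc(F)cc3Cl)cc2C1`. It differs from compound 3 in one place: 2-chloro-4-fluorophenyl in place of 2-methylphenyl on an amide-type nitrogen. In words, 2-chloro-4-fluorophenyl stands in place of 2-methylphenyl on an amide-type nitrogen.

Going by the values given here, no measured pair isolates this change, and compound 1 differs from compound 3 in more than one place, so the gap between them cannot be assigned to any single group. The data therefore offer only weak guidance. The expected change is small and, if anything, upward, with an estimated 1.8-fold higher number from compound 3 to compound 4 (0.26 log units; within the scatter) that stays within the scatter. The range is left wider on the upper side, as compound 1 at 30000 nM shows that much higher numbers occur in this small set. For compound 4 the estimated value is 2000 nM, with an expected range from 500 nM to 10000 nM.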

Compound 4, half-maximal cytotoxic concentration: 30000 nM
Compound 4: the middle estimate sits 15-fold (1.18 log units) below what was measured; the whole stated range lies below it.
By their numbers in this assay, from the lowest: compound 3; then compounds 1 and 4 (each within the scatter of the next).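

In this assay, for the compounds shown here, the change to 2-chloro-4-fluorophenyl in place of 2-methylphenyl on an amide-type nitrogen gives a 27-fold higher number from compound 3 to compound 4 (1.44 log units; beyond the scatter) and is the first step in this set that isolates a single place. Going by these compounds alone, it shows that the group on this nitrogen can, on its own, move the read-out well beyond the scatter and towards lower toxicity in this test while the rest of the molecule stays the same, which the earlier compounds, differing in more than one place, could not show. Nothing measured here says why this step is so large.

The compounds shown leave open which part of the change carries the step, since the chlorine and the fluorine enter together as the methyl leaves, and only a phenyl bearing one of these two halogens could separate them. Also open, going by these compounds, is how the read-out would respond to an amine or a carboxylic acid on this phenyl ring, and whether the step would hold with a different acyl group at the other end of the molecule.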